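Fluoro for Trifluoromethyl on a Fused Aromatic Core

The source may report more compounds than this note shows. Statements on the series, on what has been measured and on what is new or still open speak of the compounds shown alone.

Measured compounds:
- Compound 1, `CCn1nnc2c(Br)cccc21`: "not determined" (no result reported) in an ADME assay on microsomes from liver (Homo sapiens) for metabolic stability, tested at 2.5 uM; a higher number here means faster removal of the compound, a lower number slower removal
- Compound 2, `FC(F)(F)c1cc(Br)c2nnn(CC3CC3)c2c1`: 0.1 mL/min/g

In this assay, for the measured compounds named here, compound 2 gives 0.1 mL/min/g, the only number available in this set, since compound 1 has no reported result. Compound 2 therefore stands alone, with a low reading that points to slow removal.

The step to compound 3, `Fc1cc(Br)c2nnn(CC3CC3)c2c1`, changes one group: fluoro in place of trifluoromethyl on an aromatic carbon. Going by the values given here, no measured pair showing this change exists here, so the size of its effect in this assay is unknown.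

With only a single anchor, the expectation is a step no larger than the usual scatter, perhaps a slight move toward faster removal. The step from compound 2 to compound 3 is estimated as a 1.5-fold higher number from compound 2 to compound 3 (0.18 log units; within the scatter). Compound 3 is expected to give about 0.15 mL/min/g, within a range from 0.05 mL/min/g to 0.5 mL/min/g.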

Compound 3, intrinsic clearance in a liver preparation (reported as CLH), per the amount of preparation that the assay uses: 0.4 mL/min/g
Compound 3: the middle estimate sits 2.7-fold (0.43 log units) below what was measured; the measured number falls inside the stated range.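

In this assay, replacing trifluoromethyl with fluoro gives a 4.0-fold higher number from compound 2 to compound 3 (0.60 log units; beyond the scatter). This shows that the group on this aromatic carbon, para to a fused ring, can shift the rate of removal by more than repeat measurements would usually differ, which a single reading from compound 2 could not reveal. No supporting measurement accounts for this step.

The compounds shown do not reveal whether the faster removal follows from losing trifluoromethyl or from gaining fluoro, and a hydrogen, methyl or nitrile at this carbon would help separate the two. On these data alone, it also remains open whether the same change would give a similar step with different groups elsewhere on the shared core, as compound 1 offers no number for comparison.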